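Capping the hydroxy: from compound 3 to compound 4

The source may hold more compounds than are shown below. What is called first, only, known or untested is meant among the compounds shown, and "the series" means these compounds.

Measured so far:
- compound 1 `Cc1c(/N=C/c2ccc(N(C)C)cc2)c(=O)n(-c2ccccc2)n1C`: 871000000 nM
- compound 2 `COc1ccc(/C=N/c2c(C)n(C)n(-c3ccccc3)c2=O)cc1`: 977000000 nM
- compound 3 `Cc1c(/N=C/c2cccc(O)c2)c(=O)n(-c2ccccc2)n1C`: 372000000 nM

In a functional assay on DLD-1 cells (Homo sapiens) for cytotoxicity, read by MTT assay, with a stated time of 72 h (on this read-out lower numbers stand for stronger inhibition and higher numbers for weaker inhibition), compound 3 gives the lowest of the three numbers; its steps to compound 1 and compound 2 both lie beyond the scatter. Compound 4 `COc1cccc(/C=N/c2c(C)n(C)n(-c3ccccc3)c2=O)c1` differs from compound 3 by methyl in place of hydrogen on an oxygen on an aromatic ring. Within the data shown here, no measured step covers this exact change. The step of a 1.1-fold higher number from compound 1 to compound 2 (0.05 log units; within the scatter) swaps one group for another on the same aromatic carbon and stays within the scatter, while a 2.6-fold lower number from compound 2 to compound 3 (0.42 log units; beyond the scatter) changes both group and position and is modest. Compound 4 shares the methoxy of compound 2 and the placement of compound 3, so a number between them is expected, the step of a 1.6-fold higher number from compound 3 to compound 4 (0.21 log units; within the scatter) pointing upward but only weakly. Compound 4 is therefore estimated at 600000000 nM, within 250000000 nM to 1500000000 nM.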

Compound 4, half-maximal inhibitory concentration: 832000000 nM
Beside the measured number, compound 4's estimate is 1.4-fold (0.14 log units) below it; low and high end bracket the measured number.
By their numbers in this assay, from the lowest: compound 3; then compounds 4, 1 and 2 (each within the scatter of the next).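

In this assay, this step changes only what sits on the oxygen, and putting methyl in place of the hydrogen gives a 2.2-fold higher number from compound 3 to compound 4 (0.35 log units; beyond the scatter). Moving the methoxy gives a 1.2-fold lower number from compound 2 to compound 4 (0.07 log units; within the scatter), so among these compounds the lower number of compound 3 goes with the free hydroxy rather than with the placement alone. No evidence here explains this difference. Still open, on these data alone, is whether an amine or a carboxylic acid in place of the hydroxy would lower the number further, and how 4-hydroxyphenyl would compare with 3-hydroxyphenyl.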